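This account rests on a few compounds, and the source may have more. Where it says the series, first, only, none or still open, it means among the compounds named here.

Measured compounds:
- compound 1, `CN(C)c1ccccc1Nc1nccc(-c2ccncc2)n1`: 36200 nM
- compound 2, `Oc1ccc(Nc2nccc(-c3cccnc3)n2)cc1`: 5100 nM
- compound 3, `COc1ccccc1Nc1nccc(-c2cccnc2)n1`: 9800 nM

All three numbers come from a functional assay for inhibition, with Homo sapiens as the target; on this read-out higher numbers stand for weaker inhibition and lower numbers for stronger inhibition. Compound 1 gives the highest number of the three, and both gaps lie beyond the scatter: compound 3 sits closest to it, compound 2 furthest, so compound 1 is the weakest inhibitor of this set. Among the measured compounds shown here, no pair among the measured compounds differs in a single place, so no single-point step can be read off; of compounds 1 and 3 one can say only that compound 3 carries a methoxy where compound 1 carries a dimethylamino and that its number is lower, while the attached aromatic ring also differs between them.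

The next compound, compound 4, `Cc1ccccc1Nc1nccc(-c2ccncc2)n1`, changes compound 1 in one place: methyl in place of dimethylamino on an aromatic carbon.

Without a measured step of this kind, the expectation rests on the position of compound 1 at the top of the range and on the fact that every other group tried at this ring gives a lower number. A modest move toward lower numbers is expected in this assay, possibly not beyond the scatter. The expected step is a 2.0-fold lower number from compound 1 to compound 4 (0.30 log units; within the scatter). Compound 4 is estimated at 18000 nM, with a range from 5000 nM to 60000 nM.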

Compound 4, half-maximal inhibitory concentration: 3900 nM
Compound 4: middle estimate off by 4.6-fold (0.66 log units), on the high side; the whole stated range lies above it.
By their numbers in this assay, from the lowest: compounds 4, 2 and 3 (each within the scatter of the next, the first and the last beyond it); then compound 1.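

In this assay, among the compounds shown here, this is the first step that isolates the group on this aromatic carbon, ortho to a large group: methyl in place of dimethylamino gives a 9.3-fold lower number from compound 1 to compound 4 (0.97 log units; beyond the scatter). The earlier compounds shown here could not show this, since the group at this position and the attached aromatic ring differ together between compound 1 and compound 3, whereas here the attached ring stays fixed and the number still moves beyond the scatter. The change also swaps a larger group carrying a hydrogen-bond acceptor for a smaller one without an acceptor, and no data in hand separate these two differences or explain the step.

The compounds shown leave open whether the lower number belongs to methyl itself or would also appear with plain hydrogen, ethyl, chlorine or a primary amine at this position on the core of compound 4. Also open, on these data alone, is how methoxy behaves on that same core, and whether the step from dimethylamino to methyl carries over to the attached aromatic ring of compound 3.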